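A different aryl group on the carbonyl carbon

This account rests on a few compounds, and the source may have more. Where it says the series, first, only, none or still open, it means among the compounds named here.

In an assay (strain Wistar) for displacement of a labelled ligand from adenosine receptor A1 (Rattus norvegicus), read by scintillation counting (on this read-out lower numbers stand for stronger inhibition and higher numbers for weaker inhibition), compound 2 `O=C(Nc1nc(-c2ccccc2)nc2c1nnn2Cc1ccccc1)c1ccccc1F` gives 40 nM, the lowest of the two numbers shown, while compound 1 `COc1ccccc1C(=O)Nc1nc(-c2ccccc2)nc2c1nnn2Cc1ccccc1` gives 1520 nM. Among the measured compounds shown here, the single measured step, a 38-fold lower number from compound 1 to compound 2 (1.58 log units; beyond the scatter), also exchanges the group on the carbonyl carbon, but not in the same way. Compound 3 `Cc1ccc(C(=O)Nc2nc(-c3ccccc3)nc3c2nnn3Cc2ccccc2)cc1` differs from compound 2 in one place: 4-methylphenyl in place of 2-fluorophenyl on a carbonyl carbon. For the measured compounds named here, no measured step covers this exchange, so a moderate move toward higher numbers is expected, with wide uncertainty. Compound 3 is therefore estimated at 150 nM, within 30 nM to 800 nM. The expected step is a 3.8-fold higher number from compound 2 to compound 3 (0.57 log units; beyond the scatter).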

Compound 3, inhibition constant: 709 nM
For compound 3 the middle estimate is 4.7-fold (0.67 log units) below the measured one; the measured number falls inside the stated range.
By their numbers in this assay, from the lowest: compound 2; then compound 3; then compound 1.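

In this assay there is an 18-fold higher number from compound 2 to compound 3 (1.25 log units; beyond the scatter) so a second aryl group on the carbonyl carbon, 4-methylphenyl, also falls well short of 2-fluorophenyl. Set against the 2-methoxyphenyl group, there is only a 2.1-fold lower number from compound 1 to compound 3 (0.33 log units; beyond the scatter) so among these three groups 2-fluorophenyl stands well apart from the other two. Nothing given here explains these differences.

The exchange of 2-fluorophenyl for 4-methylphenyl alters both the substituent and its place on the ring, and the compounds shown cannot separate the two. On these data alone, how plain phenyl, a pyridine ring or an amine would behave on this carbonyl carbon remains open.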